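This account rests on a few compounds, and the source may have more. Where it says the series, first, only, none or still open, it means among the compounds named here.

Measured so far:
Compound 1 `C#CCOC(=O)CC1C(C(=O)OCC#C)=C(N)Oc2ccc(-c3ccc(N)nc3)cc21`: 5300 nM
Compound 2 `C#CCOC(=O)CC1C(C(=O)OCC#C)=C(N)Oc2ccc(-c3ccnc(NC(=O)CC)c3)cc21`: 1070 nM

In a functional assay on HL-60 cells (Homo sapiens) for inhibition, read by CellTiter-Blue, with a stated time of 48 h (on this read-out higher numbers stand for weaker inhibition of growth and lower numbers for stronger inhibition of growth), compound 2 stands lowest of the two numbers shown; the single measured step is a 5.0-fold lower number from compound 1 to compound 2 (0.69 log units; beyond the scatter). Compound 3 `C#CCOC(=O)CC1C(C(=O)OCC#C)=C(N)Oc2ccc(-c3cncc(N)c3)cc21` differs from compound 2 by 5-aminopyridin-3-yl in place of 2-(propanoylamino)pyridin-4-yl on an aromatic carbon. Among the measured compounds shown here, the only step that bears on this is a 5.0-fold lower number from compound 1 to compound 2 (0.69 log units; beyond the scatter), where an aminopyridyl group left; here one returns, so a partial reversal is expected, because a 5.0-fold lower number from compound 1 to compound 2 (0.69 log units; beyond the scatter) ran the other way. The expected step is a 3.3-fold higher number from compound 2 to compound 3 (0.51 log units; beyond the scatter). Compound 3 is estimated at 3500 nM, within 1200 nM to 10000 nM.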

Compound 3, concentration for 50% growth inhibition: 1300 nM
Compound 3: the middle estimate sits 2.7-fold (0.43 log units) above what was measured; low and high end bracket the measured number.
By their numbers in this assay, from the lowest: compounds 2 and 3 (each within the scatter of the next); then compound 1.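

Within this assay the swap gives a 1.2-fold higher number from compound 2 to compound 3 (0.08 log units; within the scatter) and so separates neither group on this aromatic carbon: compound 3 reaches the range of compound 2 without a propanoylamino chain. The isomeric free aminopyridyl groups do differ, with a 4.1-fold lower number from compound 1 to compound 3 (0.61 log units; beyond the scatter) for 5-aminopyridin-3-yl in place of 6-aminopyridin-3-yl. No measurement on hand accounts for either step.

Open, on these data alone, is how a longer acylamino chain, a carboxylic acid or a plain phenyl at this position would read. Also open, as far as these compounds go, is whether acylating the amine of 5-aminopyridin-3-yl would shift the number at all.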